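Cyclohexyl to Isopropyl Swap on a Kinase Inhibitor Core

The source may hold more compounds than are shown below. What is called first, only, known or untested is meant among the compounds shown, and "the series" means these compounds.

Measured compounds:
compound 1 `CC[C@@H]1C(=O)Nc2cnc(Nc3ccc(C(=O)NC4CCN(C)CC4)cc3OC)nc2N1C(C)C`, 2620 nM
compound 2 `CC[C@@H]1C(=O)Nc2cnc(Nc3ccc(C(=O)NC4CCN(C)CC4)cc3OC)nc2N1C1CCCCC1`, 37.2 nM
compound 3 `COc1cc(C(=O)NC2CCN(C)CC2)ccc1Nc1ncc2c(n1)N(C1CCCCC1)[C@H](C)C(=O)N2C`, 8.6 nM

In an assay on isolated protein for inhibition of serine/threonine-protein kinase PLK1 (Homo sapiens), read by Z'-LYTE (a higher number here means a weaker inhibitor, a lower number a stronger inhibitor), compound 2 gives 37.2 nM, while compound 1 gives 2620 nM. The two differ by isopropyl in place of cyclohexyl on a nitrogen on an aromatic ring in a ring, and that step is a 70-fold higher number from compound 2 to compound 1 (1.85 log units; beyond the scatter). Compound 3 gives 8.6 nM; how its core differs from that of compound 2 is not broken down here. Compound 4 `COc1cc(C(=O)NC2CCN(C)CC2)ccc1Nc1ncc2c(n1)N(C(C)C)[C@H](C)C(=O)N2C` has not yet been measured; it differs from compound 3 by isopropyl in place of cyclohexyl on a nitrogen on an aromatic ring in a ring. This is the same kind of change as before, not the same: in compound 3 the nitrogen is next to the ring atom that bears a methyl group, in compound 2 next to the ring atom that bears an ethyl group. Because the earlier step was a 70-fold higher number from compound 2 to compound 1 (1.85 log units; beyond the scatter), a comparable weakening is expected in this assay, estimated as a 58-fold higher number from compound 3 to compound 4 (1.76 log units; beyond the scatter). Compound 4 is therefore expected to give about 500 nM, probably between 150 nM and 2000 nM.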

Compound 4, half-maximal inhibitory concentration: 25.2 nM
Compound 4: the middle estimate sits 20-fold (1.30 log units) above what was measured, and the stated range ends above it.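

In this assay, putting isopropyl in place of cyclohexyl weakens the compound on both cores, but here the step is only a 2.9-fold higher number from compound 3 to compound 4 (0.47 log units; beyond the scatter). The direction of the change carried over from one core to the other, while its size did not: the same change on two cores in this assay, a 70-fold higher number (1.85 log units; beyond the scatter) from compound 2 to compound 1 and a 2.9-fold higher number (0.47 log units; beyond the scatter) from compound 3 to compound 4, 24-fold (1.38 log units) apart, beyond the scatter of two such steps

This does not show which difference between the two cores sets the steps apart, and two cores cannot tell how the same swap would behave on a third.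

The compounds shown leave open how a different group on that nitrogen, such as cyclopentyl or a longer chain like n-butyl, would behave on either core. Going by these compounds, whether the same gap between the cores appears outside this assay also stays open.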